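Terminal amine swap in the series: compound 2 to compound 3

This account rests on a few compounds, and the source may have more. Where it says the series, first, only, none or still open, it means among the compounds named here.

Measured so far:
compound 1 `CCN(CC)CCCNc1ccnc2cc(C(F)(F)F)ccc12` gives 20600 nM in a functional assay on MCF7 cells (Homo sapiens) for antiproliferative activity, read by sulforhodamine B assay, with a stated time of 48 h; on this read-out higher numbers stand for weaker inhibition of growth and lower numbers for stronger inhibition of growth
compound 2 `FC(F)(F)c1ccc2c(NCCCN3CCCCC3)ccnc2c1` gives 32600 nM in this assay

Among the measured compounds shown here, on the numbers so far compound 2 carries the higher of the two values, but the step of a 1.6-fold higher number from compound 1 to compound 2 (0.20 log units; within the scatter) lies within the scatter, so compound 1 and compound 2 cannot be separated on this read-out.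

Compound 3 `CN1CCN(CCCNc2ccnc3cc(C(F)(F)F)ccc23)CC1`, not yet measured, differs from compound 2 by 4-methylpiperazin-1-yl in place of piperidin-1-yl on a saturated chain carbon, three bonds along the chain from a nitrogen on an aromatic ring. For the measured compounds named here, only one measured step bears on this change: a 1.6-fold higher number from compound 1 to compound 2 (0.20 log units; within the scatter), itself an exchange of the terminal amine at the same place on the chain, and it stayed within the scatter. Going by the values given here, no measured pair shows what the second ring nitrogen of the entering group does on this read-out, so the expectation rests on that single flat step alone.

The expected step in this assay is a 1.1-fold lower number from compound 2 to compound 3 (0.04 log units; within the scatter), that is, none beyond the scatter. Compound 3 is accordingly estimated at 30000 nM, with a range from 10000 nM to 90000 nM.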

Compound 3, concentration for 50% growth inhibition: 30800 nM
Estimate against measurement, compound 3: 1.0-fold (0.01 log units) below, and the stated range covers the measured number.
By their numbers in this assay, from the lowest: compounds 1, 3 and 2 (each within the scatter of the next).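

In this assay the terminal group on a saturated chain carbon, three bonds along the chain from a nitrogen on an aromatic ring, now also covers a ring with 2 hetero atoms, and 4-methylpiperazin-1-yl cannot be separated from piperidin-1-yl (a 1.1-fold lower number from compound 2 to compound 3 (0.02 log units; within the scatter)) or from diethylamino (a 1.5-fold higher number from compound 1 to compound 3 (0.17 log units; within the scatter)). Among the compounds shown here, the earlier pair compared only a ring with 1 hetero atom against an open-chain amine, so this is the first sign that a further ring nitrogen with its methyl leaves the read-out inside the scatter, and across these three compounds no exchange of the terminal amine stands beyond it. Nothing measured here accounts for this flat behaviour.

Still open, on these data alone, is whether a terminal group of another kind, such as morpholin-4-yl, a primary amine or a carboxylic acid, would give a step beyond the scatter at this place. As far as these compounds go, a longer or shorter chain between the two nitrogens, and any exchange of the trifluoromethyl on the shared core, also remain untested by these compounds as a source of a larger step.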